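This account rests on a few compounds, and the source may have more. Where it says the series, first, only, none or still open, it means among the compounds named here.

Of the compounds shown here, two built on one shared core have been tested in a functional assay on the whole organism (strain albino) for inhibition, with Rattus norvegicus as the target, read by paw edema, with stated times of 1 h and 4 h, at a dose of 200 mg/kg by the oral route; on this read-out higher numbers stand for more inhibition at the one dose given (going by the name of the read-out) and lower numbers for less inhibition. Compound 1, `O=c1oc2ccccc2cc1C1=NN(c2ccccc2)[C@@H](c2ccccc2)C1`, gives 32.7% in this assay. Compound 2, `O=c1oc2ccccc2cc1C1=NN(c2ccccc2)[C@@H](c2ccccc2[N+](=O)[O-])C1`, gives 26.6% in this assay. Going by the values given here, the single measured step between them, a number 6.1 percentage points lower from compound 1 to compound 2 (within the scatter), is a nitro in place of hydrogen on an aromatic carbon. Among the compounds with values here, compound 2 thus holds the lower of the two numbers, yet its only neighbour, compound 1, sits within the scatter of it, so the two are not distinguishable.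

Compound 3, `O=c1oc2ccccc2cc1C1=NN(c2ccccc2)[C@@H](c2ccc(O)cc2)C1`, is the next compound, not yet measured. It differs from compound 2 by 4-hydroxyphenyl in place of 2-nitrophenyl on a saturated ring carbon. Within the data shown here, the only measured step that bears on this is a number 6.1 percentage points lower from compound 1 to compound 2 (within the scatter), which shows that adding the nitro group moved the read-out only within the scatter; its removal should likewise move little. The 4-hydroxyphenyl group itself has no measured counterpart among these compounds. The expected step in this assay, a number 4.4 percentage points higher from compound 2 to compound 3 (within the scatter), is therefore none beyond the scatter. Compound 3 is estimated to give 31%, with a likely range from 18% to 44%.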

Compound 3, a percentage reported as inhibition, in the whole organism at one dose (the size of the read-out at that dose, not a potency): 34.6%
Compound 3: the middle estimate sits 3.6 percentage points below what was measured; low and high end bracket the measured number.
By their numbers in this assay, from the lowest: compounds 2, 1 and 3 (each within the scatter of the next).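

Placing 4-hydroxyphenyl in the spot of 2-nitrophenyl on the saturated ring carbon gives a number 8 percentage points higher from compound 2 to compound 3 (within the scatter) in this assay, while adding a hydroxy to the plain phenyl group gives a number 1.9 percentage points higher from compound 1 to compound 3 (within the scatter). This position has now held phenyl, 2-nitrophenyl and 4-hydroxyphenyl, the last bringing a hydrogen-bond donor, and no step among these three compounds stands clear of the scatter. No independent evidence is available to explain this result.

Going by these compounds, it remains open whether any group at this carbon can move the read-out beyond the scatter, for example an amine or a carboxylic acid on the phenyl ring, or a butyl chain in place of the ring. On these data alone, with only one dose given, how these compounds compare at other doses also remains open.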